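The source may report more compounds than this note shows. Statements on the series, on what has been measured and on what is new or still open speak of the compounds shown alone.

Measured compounds:
compound 1, `COC(=O)C(c1ccccc1Cl)N1CCC(O)(Cn2cnc3c(cnn3-c3ccc(F)cc3)c2=O)CC1` — "not determined" (no result reported)
compound 2, `O=c1c2cnn(-c3ccc(F)cc3)c2ncn1CC1(O)CCN(Cc2ccccc2Cl)CC1` — 3400 nM

The study is read in an assay on Sf21 cells for inhibition of ubiquitin carboxyl-terminal hydrolase 7 (Homo sapiens), read by spectrophotometry, with stated times of 30 min and 2 h; on this read-out lower numbers stand for stronger inhibition and higher numbers for weaker inhibition. Compound 1 carries a methoxycarbonyl-bearing branch on the nitrogen of the piperidine of the shared core but no result was reported for it. Within the data shown here, compound 2 is therefore the only compound with a number: in this assay compound 2 gives 3400 nM, and it stands alone, with nothing to order it against.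

Compound 3, `COC(=O)c1ccc(CN2CCC(O)(Cn3cnc4c(cnn4-c4ccc(F)cc4)c3=O)CC2)c(Cl)c1`, is not yet measured. It differs from compound 2 in one place: methoxycarbonyl in place of hydrogen on an aromatic carbon This places a methoxycarbonyl on the chlorobenzyl group, meta to a chloro group and para to a large group, turning the 2-chlorobenzyl of compound 2 into a 2-chloro-4-(methoxycarbonyl)benzyl.

Among the measured compounds shown here, no pair of measured compounds shows what such a change does in this assay, so there is no step to lean on. Compound 3 is therefore expected to sit close to compound 2, with a step of a 1.1-fold lower number from compound 2 to compound 3 (0.05 log units; within the scatter) that is expected to stay within the scatter. The estimate for compound 3 in this assay is 3000 nM, expected to fall between 1000 nM and 9000 nM.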

Compound 3, half-maximal inhibitory concentration: 800 nM
Compound 3: middle estimate off by 3.8-fold (0.57 log units), on the high side, and the stated range ends above it.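

In this assay, among these compounds, the change from the 2-chlorobenzyl group to the 2-chloro-4-(methoxycarbonyl)benzyl group gives a 4.3-fold lower number from compound 2 to compound 3 (0.63 log units; beyond the scatter), the first step that can be read, and a modest one. It shows that this aromatic carbon, meta to a chloro group and para to a large group, takes a methoxycarbonyl with a gain rather than a loss of inhibition, something the lone value of compound 2 could not show. No measurement shown here bears on what lies behind this step.

Going by these compounds, the step rests on one group at one position, so it remains open whether a carboxylic acid, a primary amide or a nitrile on the same aromatic carbon would move the number the same way, or whether a methoxycarbonyl on another carbon of that ring would do so. Compound 1, with its methoxycarbonyl on the branch at the piperidine nitrogen, stands at "not determined" (no result reported), so it offers no comparison between that placement and the one on the aromatic ring.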